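This account rests on a few compounds, and the source may have more. Where it says the series, first, only, none or still open, it means among the compounds named here.

Measured in an ADME assay on MT4 cells (Homo sapiens) for cytotoxicity, with a stated time of 5 days; on this read-out higher numbers stand for lower toxicity in this test and lower numbers for higher toxicity in this test:
- compound 1 `CC(C)(C)C#Cc1cc(N(C(=O)[C@H]2CC[C@H](C)CC2)[C@H]2CC[C@H](Oc3ccc4nccn4n3)CC2)c(C(=O)O)s1`: > 20000 nM
- compound 2 `CC(C)N(C(=O)C1CCCCC1)c1cc(C#CC(C)(C)C)sc1C(=O)O`: > 20000 nM

Compound 2 gives only a limit of the assay, > 20000 nM, and not a number. Compound 1 likewise gives only a limit, > 20000 nM. The two measured compounds therefore stand together at the limit of > 20000 nM in this assay, at which 2 of the 2 values shown sit. Among the measured compounds shown here, neither value gives a number from which to read a difference, and no step between measured compounds is available.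

The next compound is compound 3 `CC(C)N(C(=O)C1CCCCCC1)c1cc(C#CC(C)(C)C)sc1C(=O)O`. It has cycloheptyl in place of cyclohexyl on a carbonyl carbon whose other neighbour is the amide-type nitrogen, and the rest of compound 2 is unchanged: cycloheptyl in place of cyclohexyl on a carbonyl carbon.

The expected change is a number no higher from compound 2 to compound 3 (the limit leaves the size open), estimated to stay within the scatter in this assay, with no direction favoured. This expectation rests on compound 2, whose limit is > 20000 nM, and on the small size of the ring change. Another reading at the limit is the most likely outcome. For compound 3 the estimated value is 20000 nM, with an expected range from 10000 nM to 40000 nM.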

Compound 3, half-maximal cytotoxic concentration: > 20000 nM
Compound 3: a limit, no number; the forecaster's own chance of this, stated with the estimate: 80%; the middle value sits exactly at the limit.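

In this assay compound 3 gives > 20000 nM, a limit and not a number. Compound 2 also gives a limit, > 20000 nM, so no step can be read between compound 2 and compound 3. The compounds shown leave open what number any of them would reach and whether cycloheptyl in place of cyclohexyl on a carbonyl carbon alters it, since all stand together: the limit of > 20000 nM in this assay, at which 3 of the 3 values shown sit.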